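Pyridyl Ester to Butyl Carbamate: an Expected Gain

The compounds below may be only part of what the source reports. "The series", "measured", "known", "first", "only" and "open" are said of these compounds alone.

Measured compounds:
compound 1 `COc1nc(C)c(Nc2nc(Cl)cn([C@H](COC(=O)c3ccccn3)C3CC3)c2=O)cc1C` — 67 nM
compound 2 `CCCNC(=O)OC[C@H](C1CC1)n1cc(Cl)nc(Nc2cc(C)c(OC)nc2C)c1=O` — 10 nM

In an assay on frontal cortex for displacement of a labelled ligand from corticotropin-releasing factor receptor 1 (Rattus norvegicus), with a stated time of 2 h (a lower number here means a stronger inhibitor, a higher number a weaker inhibitor), compound 1 gives 67 nM, the highest number of the two measured compounds; its nearest neighbour is compound 2, and the step of a 6.7-fold lower number from compound 1 to compound 2 (0.83 log units; beyond the scatter) is modest but beyond the scatter. Compound 3 `CCCCNC(=O)OC[C@H](C1CC1)n1cc(Cl)nc(Nc2cc(C)c(OC)nc2C)c1=O` has not yet been measured. It differs from compound 1 as follows: butylamino in place of pyridin-2-yl on a carbonyl carbon. Going by the values given here, only one measured step bears on this change, the one from compound 1 to compound 2, in which propylamino replaced pyridin-2-yl on the same carbonyl carbon and gave a 6.7-fold lower number from compound 1 to compound 2 (0.83 log units; beyond the scatter). Butylamino is a close relative of propylamino, so the step in this assay from compound 1 to compound 3 is expected to be of similar size and in the same downward direction, that is about a 5.6-fold lower number from compound 1 to compound 3 (0.75 log units; beyond the scatter). Compound 3 is therefore estimated at 12 nM, with a likely range from 5 nM to 30 nM.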

Compound 3, half-maximal inhibitory concentration: 4.7 nM
The estimate for compound 3 lay 2.6-fold (0.41 log units) above the measured number; measured number outside the range, below it.
By their numbers in this assay, from the lowest: compound 3; then compound 2; then compound 1.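

In this assay, butylamino in place of pyridin-2-yl on the carbonyl carbon produces a 14-fold lower number from compound 1 to compound 3 (1.15 log units; beyond the scatter) and so goes further than propylamino did at this position. Adding one methyl to the end of the chain produces a 2.1-fold lower number from compound 2 to compound 3 (0.33 log units; beyond the scatter) and is a modest change, but it lies beyond the scatter, which shows that this position still responds to a small extension of the chain on the amide-type nitrogen. Nothing available explains either step.

On these data alone, two chains on the carbamate nitrogen give only a first indication of how chain length matters, and whether a pentyl or longer chain would give a lower or higher number remains open. A branched chain such as isobutyl, a cyclopropylmethyl group, or a chain ending in an amine or a carboxylic acid also remains untested among the compounds shown.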